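Oxolanylmethyl ether on the aminoquinoline core

The source may report more compounds than this note shows. Statements on the series, on what has been measured and on what is new or still open speak of the compounds shown alone.

Measured compounds: compound 1 `CC(C)Oc1cccc2ccc(N)nc12` with 437 nM in an assay on cells with melanin-concentrating hormone receptor 1 (Homo sapiens) as the target, read by radioligand binding; on this read-out lower numbers stand for stronger inhibition and higher numbers for weaker inhibition; compound 2 `Nc1ccc2cccc(OCC3CCC3)c2n1` with 432 nM in this assay.

Among the compounds with values here, compound 2 and compound 1 sit within the scatter of each other, as the single measured step shows: a 1.0-fold lower number from compound 1 to compound 2 (0.00 log units; within the scatter). Compound 3 `Nc1ccc2cccc(OCC3CCCO3)c2n1` differs from compound 2 by oxolan-2-yl in place of cyclobutyl on a saturated chain carbon bound to an oxygen on an aromatic ring. Within the data shown here, the only step that bears on this change is the one from compound 1 to compound 2, and it was within the scatter, so the ether group appears to leave this read-out little moved. Compound 3 is therefore expected to stay close to compound 2, with a 1.0-fold higher number from compound 2 to compound 3 (0.02 log units; within the scatter) as the expected step. The estimate for compound 3 is 450 nM, within a range of 200 nM to 1000 nM.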

Compound 3, half-maximal inhibitory concentration: > 2000 nM
Compound 3 was reported as a limit; the forecaster's own chance of this, stated with the estimate: 3%; middle value at least 4.4-fold (0.64 log units) away from the limit.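

Compound 3 carries a limit of the assay, not a number: the limit of > 2000 nM in this assay, at which 1 of the 3 values shown sits. Isopropyl and cyclobutylmethyl gave no hint of it, but this position on an oxygen on an aromatic ring does not accept every ether group alike, with an at least 4.6-fold higher number from compound 2 to compound 3 (0.66 log units; beyond the scatter) and an at least 4.5-fold higher number from compound 1 to compound 3 (0.66 log units; beyond the scatter). The change from cyclobutyl to oxolan-2-yl brings a five-membered ring and a ring oxygen together.

What the compounds shown leave open is which of the two goes with the higher number, a question that cyclopentyl on the same chain carbon would address. On these data alone, how far the number of compound 3 lies past its limit also stays open.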